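Swapping a Butyl Chain for an Arylsulfonyl Group

This account rests on a few compounds, and the source may have more. Where it says the series, first, only, none or still open, it means among the compounds named here.

In a functional assay on HEK293 cells (Homo sapiens) for cytotoxicity (on this read-out lower numbers stand for higher toxicity in this test and higher numbers for lower toxicity in this test), compound 1, `COc1ccc([C@H]2CC(=O)N(c3ccc(C)c(N)c3)C2)cc1OC1CCCC1`, gives > 10000 nM, a limit of the assay.
In this assay compound 2, `COc1ccc([C@H]2CC(=O)N(c3ccccc3C#N)C2)cc1OC1CCCC1`, gives > 10000 nM, again a limit.
In this assay compound 3, `CCCCNc1cccc(N2C[C@@H](c3ccc(OC)c(OC4CCCC4)c3)CC2=O)c1`, gives > 10000 nM, also a limit.

Among the compounds with values here, compound 3 therefore stands where every value so far stands: the limit of > 10000 nM in this assay, at which 3 of the 3 values shown sit. Within the data shown here, the one step among measured compounds, a step that the two limits leave unreadable from compound 1 to compound 2, cannot be read, so no measured step gives a size to lean on. Compound 4, `COc1ccc([C@H]2CC(=O)N(c3cccc(NS(=O)(=O)c4cccc(C)c4)c3)C2)cc1OC1CCCC1`, differs from compound 3 by (3-methylphenyl)sulfonyl in place of butyl on a nitrogen on an aromatic ring. With all three values sitting at the limit, the step is expected to be a step that the limit leaves unreadable from compound 3 to compound 4, that is, nothing beyond the scatter. Compound 4 is therefore expected to give about 15000 nM, in a range from 6000 nM to 40000 nM, most likely reported again as a limit.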

Compound 4, half-maximal cytotoxic concentration: > 10000 nM
Compound 4: a limit, no number; the forecaster's own chance of this, stated with the estimate: 80%; the middle value does not contradict the limit.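

Within the data shown here, compound 3 and compound 4 both give only a limit, so the step between them cannot be read, and no new step comes from this result: the limit of > 10000 nM in this assay, at which 4 of the 4 values shown sit. In this assay the compounds shown leave open whether any change of group shifts the half-maximal cytotoxic concentration at all.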